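Swapping a Chloro for a Phenyl on a Shared Core

This account rests on a few compounds, and the source may have more. Where it says the series, first, only, none or still open, it means among the compounds named here.

Of the compounds shown here, two have been measured so far. Compound 1 `CC(=O)c1ccc(Nc2ccnc(SCC(=O)c3ccc(Br)cc3)n2)cc1` and compound 2 `CC(=O)c1ccc(Nc2ccnc(SCC(=O)c3ccc(Cl)cc3)n2)cc1` share the same core and differ only in the halogen on the outer aromatic ring. In a functional assay on NCI-H226 cells (Homo sapiens) for inhibition, read by sulforhodamine B assay, with a stated time of 48 h, tested at 10 uM (a lower number here means less inhibition of growth, a higher number more inhibition of growth at the concentration tested), compound 1 gives 25%, and compound 2 gives 21%. The step of a number 4 percentage points lower from compound 1 to compound 2 (within the scatter) is a halogen swap that changes the read-out by less than the scatter, so the two compounds cannot be told apart on these numbers. Compound 2 holds the lower of the two values, but that standing carries no weight.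

Compound 3 `CC(=O)c1ccc(Nc2ccnc(SCC(=O)c3ccc(-c4ccccc4)cc3)n2)cc1` is the next compound to be measured. It differs from compound 2 in one place: phenyl in place of chloro on an aromatic carbon. Going by the values given here, no measured step concerns a ring entering at this position; the only step known, a number 4 percentage points lower from compound 1 to compound 2 (within the scatter), stays within the scatter and bears on a halogen swap, not on a phenyl. Among the compounds with values here, the data therefore give no direction for the step. For compound 3 the expected value in this assay is 27%, within a range from 8% to 50%. For compound 3 the expected step is a number 6 percentage points higher from compound 2 to compound 3 (within the scatter).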

Compound 3, percent growth inhibition at one concentration: 11%
The estimate for compound 3 lay 16 percentage points above the measured number; the measured number falls inside the stated range.
By their numbers in this assay, from the lowest: compounds 3, 2 and 1 (each within the scatter of the next, the first and the last beyond it).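

Until now, only two halogens had been compared at this aromatic carbon, para to a large group, and the change between them could not be read. Going by these compounds alone, with a ring in place of the halogen, this assay shows a number 10 percentage points lower from compound 2 to compound 3 (within the scatter), so phenyl and chloro cannot be told apart, but also a number 14 percentage points lower from compound 1 to compound 3 (beyond the scatter), the first step at this position to clear the scatter. Six heavy atoms in place of one halogen therefore bring no gain in growth inhibition over either halogen, and against bromo the change is a modest loss; no measurement at hand offers an explanation for this.

What an amine, a carboxylic acid or a longer chain would do at this same carbon remains open, since a halogen and a flat carbon ring are the only kinds of group shown here. Also open, going by these compounds, is whether changes elsewhere on the shared core would matter more, as all three compounds differ only at this one position and give modest numbers at the single concentration tested.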